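This account rests on a few compounds, and the source may have more. Where it says the series, first, only, none or still open, it means among the compounds named here.

In a functional assay on HCT-116 cells (Homo sapiens) for inhibition, read by MTT assay, with a stated time of 48 h (a higher number here means a weaker inhibitor, a lower number a stronger inhibitor), compound 1 `COc1ccc(-n2c(S)nnc2-c2cc(OC)c(OC)c(OC)c2)cc1` reads > 60000 nM, which is a limit of the assay and not a number. Compound 2 `COc1ccc(-n2c(SCc3ccc(C)cc3)nnc2-c2cc(OC)c(OC)c(OC)c2)cc1` gives 33300 nM. Compound 3 `COc1ccc(-n2c(SCc3ccc(F)cc3)nnc2-c2cc(OC)c(OC)c(OC)c2)cc1` gives 38700 nM, within the scatter of compound 2. Replacing the hydrogen on sulfur yields only floors, an at least 1.8-fold lower number from compound 1 to compound 2 (0.25 log units; that floor lies within the scatter) and an at least 1.5-fold lower number from compound 1 to compound 3 (0.19 log units; that floor lies within the scatter), so neither step fixes a size.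

Compound 4 `COc1ccc(C(=O)CSc2nnc(-c3cc(OC)c(OC)c(OC)c3)n2-c2ccc(OC)cc2)cc1` differs from compound 3 by (4-methoxyphenyl)carbonyl in place of 4-fluorophenyl on a saturated chain carbon bound to a sulfur. Going by the values given here, no measured step covers this exchange of (4-methoxyphenyl)carbonyl for 4-fluorophenyl. The nearest guide is the fluoro-for-methyl swap leading to compound 3, a 1.2-fold higher number from compound 2 to compound 3 (0.07 log units; within the scatter), which gives no basis for expecting a large shift. The expectation is therefore no change beyond the scatter, with a real chance that compound 4 reaches the assay limit. The expected step is a 1.3-fold lower number from compound 3 to compound 4 (0.11 log units; within the scatter). For compound 4 the estimated value is 30000 nM, with an expected range from 11000 nM to 60000 nM.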

Compound 4, half-maximal inhibitory concentration: > 60000 nM
Compound 4: only a limit was reported; the forecaster's own chance of this, stated with the estimate: 20%; middle value at least 2.0-fold (0.30 log units) from the limit.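

In this assay compound 4 gives > 60000 nM, which is a limit of the assay and not a number. The exchange on the saturated chain carbon bound to a sulfur therefore yields only floors, an at least 1.5-fold higher number from compound 3 to compound 4 (0.19 log units; that floor lies within the scatter) and an at least 1.8-fold higher number from compound 2 to compound 4 (0.25 log units; that floor lies within the scatter), so neither step fixes a size, and the step involving compound 1 and compound 4 cannot be read. Substituents on sulfur are thus not all alike in this series: 4-methylbenzyl and 4-fluorobenzyl give readable numbers, whereas ((4-methoxyphenyl)carbonyl)methyl, like the hydrogen of compound 1, gives only a limit: the limit of > 60000 nM in this assay, at which 2 of the 4 values shown sit.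

The exchange brings in the carbonyl and the methoxy group together, and the compounds shown do not separate the two. As far as these compounds go, whether 4-methoxybenzyl on sulfur gives a readable number, and whether a phenylcarbonylmethyl group without the methoxy does, remains open.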